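Triazole hydroxamates against histone deacetylase 8: shortening the linker

This account rests on a few compounds, and the source may have more. Where it says the series, first, only, none or still open, it means among the compounds named here.

Measured so far:
compound 1, `O=C(NO)c1cn(CCOc2ccccc2)nn1`: 26%
compound 2, `O=C(/C=C/c1cn(Cc2ccccc2)nn1)NO`: 12%

In an assay on isolated protein for inhibition of histone deacetylase 8 (Homo sapiens), tested at 0.50 uM (a higher number here means more inhibition at the concentration tested (going by the name of the read-out), a lower number less inhibition), compound 1 gives 26%, and compound 2 gives 12%. Compound 2 thus stands lowest of the two numbers, and its gap to compound 1 lies beyond the scatter of repeated measurements.

Compound 3, `O=C(NO)c1cn(Cc2ccccc2)nn1`, is not yet measured. It differs from compound 2 in one place: hydroxycarbamoyl in place of 2-(hydroxycarbamoyl)ethenyl on an aromatic carbon. The group on the ring nitrogen stays the same; only the hydroxycarbamoyl is now attached directly to the aromatic carbon rather than through the ethenyl bridge.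

Among the measured compounds shown here, no step between two measured compounds that differ only in this way is available, so the size of the change can only be guessed from what compound 1 and compound 2 show. Compound 1, which carries the directly attached hydroxycarbamoyl, sits higher in this assay than compound 2, so a modest rise is expected for compound 3, with an expected step of a number 8 percentage points higher from compound 2 to compound 3 (within the scatter), which may not exceed the scatter. Compound 3 is estimated at 20%, within a range of 5% to 40%.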

Compound 3, a percentage reported as inhibition, at one concentration (the size of the read-out at that concentration, not a potency): 12%
For compound 3 the middle estimate is 8 percentage points above the measured one; low and high end bracket the measured number.
By their numbers in this assay, from the lowest: compounds 2 and 3 (each within the scatter of the next); then compound 1.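

In this assay, replacing 2-(hydroxycarbamoyl)ethenyl with hydroxycarbamoyl on the aromatic carbon gives no change at the digits printed from compound 2 to compound 3 (within the scatter) and so, with the rest of the molecule held constant, this read-out does not distinguish the bridged from the directly attached hydroxycarbamoyl at this position. The higher number of compound 1 (26%) therefore cannot be credited to direct attachment alone: compound 3 carries the same attachment and gives 12% and differs from compound 1 only in the group on the ring nitrogen, which makes that group the place to look at next. Nothing available explains why removing the bridge leaves the number where it stands.

On these data alone, whether the ethenyl bridge would be equally silent on the core of compound 1, with its different group on the ring nitrogen, remains open. Also open is how this position would respond to a longer saturated chain leading to the hydroxycarbamoyl, or to a carboxylic acid in its place, since the compounds shown cover only the direct attachment and the ethenyl bridge.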